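The source may report more compounds than this note shows. Statements on the series, on what has been measured and on what is new or still open speak of the compounds shown alone.

Measured so far:
Compound 1, `COc1ccc(/C=C/c2cc(OC)cc(OC)c2/C=C/C(=O)Nc2cc(OC)c(OC)c(OC)c2)cc1`: 8150 nM
Compound 2, `COc1ccc(/C=C/c2cc(OC)cc(OC)c2/C=C/C(=O)N2CCCCC2)cc1`: 9750 nM

In a functional assay on B16-F10 cells (Mus musculus) for inhibition, read by MTT assay, with a stated time of 48 h (on this read-out lower numbers stand for stronger inhibition and higher numbers for weaker inhibition), compound 2 gives 9750 nM, and compound 1 gives 8150 nM; the two numbers lie within the scatter of each other, so nothing separates the aryl amide of compound 1 from the piperidine amide of compound 2 on this read-out. Going by the values given here, no step between measured compounds is available to anchor the amide part of the series.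

Compound 3, `C#CCNC(=O)/C=C/c1c(/C=C/c2ccc(OC)cc2)cc(OC)cc1OC`, is the next member. It differs from compound 2 in one place: propargylamino in place of piperidin-1-yl on a carbonyl carbon. A ring of the amide nitrogen is thus exchanged for an open chain carrying a triple bond and one hydrogen-bond donor.

Since the two measured amides sit together, no sizeable move is expected here. The step from compound 2 to compound 3 is expected to be a 1.2-fold lower number from compound 2 to compound 3 (0.09 log units; within the scatter), that is, within the scatter. Compound 3 is accordingly estimated at 8000 nM, with a range from 3000 nM to 22000 nM.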

Compound 3, half-maximal inhibitory concentration: 8280 nM
Compound 3: middle estimate off by 1.0-fold (0.01 log units), on the low side, and the stated range covers the measured number.
By their numbers in this assay, from the lowest: compounds 1, 3 and 2 (each within the scatter of the next).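

Swapping piperidin-1-yl for propargylamino on the carbonyl carbon removes the ring and adds a triple bond and a hydrogen-bond donor, yet in this assay the step stays within the scatter (a 1.2-fold lower number from compound 2 to compound 3 (0.07 log units; within the scatter)). Propargyl in place of 3,4,5-trimethoxyphenyl on the amide-type nitrogen also stays within the scatter (a 1.0-fold higher number from compound 1 to compound 3 (0.01 log units; within the scatter)), so an open chain and an aromatic ring on this nitrogen are not separated on this read-out. No measurement on hand explains this insensitivity.

As far as these compounds go, whether any replacement at this position can produce a step beyond the scatter remains open, for example a carboxylic acid on the carbonyl carbon or a dimethylaminoethyl chain on the nitrogen. From the compounds shown here alone, the contribution of the shared core also remains open, since all three compounds carry it unchanged.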